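A few compounds are considered here, and "the series" means these few. Any claim that something is new, unique, unknown or untested is made for them only; others in the source may bear on it.

Measured so far in an assay on isolated protein for inhibition of Amine oxidase [flavin-containing] A (Homo sapiens), read by fluorescence and Amplex Red, with a stated time of 30 min, tested at 0.1 nM; a higher number here means a stronger effect of the compound at the concentration tested, a lower number a weaker effect:
- compound 1 `CCCCNc1nnc(SCC(=O)N(Cc2cccc([N+](=O)[O-])c2)c2ccc(F)cc2)s1` gives 11.1%
- compound 2 `COCCNc1nnc(SCC(=O)N(Cc2cccc([N+](=O)[O-])c2)c2ccc(F)cc2)s1` gives 20.1%
- compound 3 `C=CCNc1nnc(SCC(=O)N(Cc2cccc([N+](=O)[O-])c2)c2ccc(F)cc2)s1` gives 13.5%

Compound 1 has the lowest of the three numbers, but its gaps to both others are within the scatter: a number 9 percentage points higher from compound 1 to compound 2 (within the scatter) and a number 2.4 percentage points higher from compound 1 to compound 3 (within the scatter). The pair of compounds 2 and 3 is likewise within the scatter, a number 6.6 percentage points lower from compound 2 to compound 3 (within the scatter). Across these three compounds the chain on the nitrogen of the shared core has been varied without any step beyond the scatter.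

Compound 4 `CCNc1nnc(SCC(=O)N(Cc2cccc([N+](=O)[O-])c2)c2ccc(F)cc2)s1` differs from compound 1 in one place: hydrogen in place of ethyl on a saturated chain carbon, two bonds along the chain from a nitrogen on an aromatic ring. This change shortens the same chain that was varied in the measured steps. All three of those steps bear on it, and none of them exceeded the scatter, so no step beyond the scatter is expected here either: the estimated step is a number 1.9 percentage points higher from compound 1 to compound 4 (within the scatter). Compound 4 is therefore expected to give about 13%, with a range from 4% to 24%.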

Compound 4, a percentage reported as inhibition, at one concentration (the size of the read-out at that concentration, not a potency): 14.2%
Estimate against measurement, compound 4: 1.2 percentage points below; the range from low to high includes it.
By their numbers in this assay, from the lowest: compounds 1, 3, 4 and 2 (each within the scatter of the next).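

Cutting butylamino to ethylamino in this assay gives no step beyond the scatter (a number 3.1 percentage points higher from compound 1 to compound 4 (within the scatter)), so shortening this chain joins the earlier exchanges in leaving the read-out unresolved. Compound 4 also stays within the scatter of the vinyl and methoxy chains (a number 0.7 percentage points higher from compound 3 to compound 4 (within the scatter); a number 5.9 percentage points lower from compound 2 to compound 4 (within the scatter)), and no step beyond the scatter has been seen at this position among compound 1, compound 2, compound 3 and compound 4. No supporting measurement bears on this result.

The compounds shown leave open whether a longer chain, a phenyl ring, or a terminal amine or carboxylic acid on the chain would give a step beyond the scatter. They also leave open whether replacing the whole ethylamino group with a plain amino group would do so.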